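The source may report more compounds than this note shows. Statements on the series, on what has been measured and on what is new or still open speak of the compounds shown alone.

Measured compounds in this study:

compound 1 `OC(/C=C/c1cccc(Cl)c1)c1nc2ccccc2[nH]1`: > 100000 nM

compound 2 `COc1cccc(/C=C/C(O)c2nc3ccccc3[nH]2)c1`: > 100000 nM

compound 3 `O=C(/C=C/c1cccc(Cl)c1)c1nc2ccccc2o1`: > 100000 nM

All three were tested in a functional assay on MCF7 cells (Homo sapiens) for antiproliferative activity, read by MTT assay, with a stated time of 48 h; a lower number here means a stronger inhibitor, a higher number a weaker inhibitor. For compound 1 the value is only a limit of the assay, not a number. For compound 2 the value is likewise only a limit. For compound 3 the value is again only a limit. The change from compound 1 to compound 2 is methoxy in place of chloro on an aromatic carbon, and the resulting step that the two limits leave unreadable from compound 1 to compound 2 cannot be sized because of the limit of > 100000 nM in this assay, at which 3 of the 3 values shown sit. The difference between the core of compound 1 and the core of compound 3 is not broken down here. Compound 4 `COc1cccc(/C=C/C(=O)c2nc3ccccc3o2)c1` differs from compound 3 by the same change, (methoxy in place of chloro on an aromatic carbon). Since compound 3 already sits at the limit of > 100000 nM in this assay, at which 3 of the 3 values shown sit, the step from compound 3 to compound 4 is expected to be a step that the limit leaves unreadable from compound 3 to compound 4. Compound 4 is therefore estimated at 150000 nM, within 30000 nM to 1000000 nM, most likely reported only as a limit.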

Compound 4, half-maximal inhibitory concentration: > 100000 nM
Compound 4 was reported as a limit; the forecaster's own chance of this, stated with the estimate: 85%; the middle value does not contradict the limit.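

The step from compound 3 to compound 4 cannot be read, as both values are only limits: the limit of > 100000 nM in this assay, at which 4 of the 4 values shown sit.

The compounds shown leave open whether swapping chloro for methoxy changes activity at all, and what change to these structures would give a measurable number.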